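Halogen swap on a fused thiadiazine core

This account rests on a few compounds, and the source may have more. Where it says the series, first, only, none or still open, it means among the compounds named here.

Measured so far:
compound 1 `CC(C)Cc1ccc(C(C)c2n[nH]c(=S)n2N)cc1`, 11700 nM
compound 2 `CC(c1ccc(-c2ccccc2)c(F)c1)c1nnc2n1N=C(c1ccc(Cl)cc1Cl)CS2`, 4700 nM
compound 3 `COc1ccc2cc(C(C)c3n[nH]c(=S)n3N)ccc2c1`, 15900 nM

In a functional assay on SNU-475 cells (Homo sapiens) for inhibition, read by sulforhodamine B assay, with a stated time of 72 h (a lower number here means a stronger inhibitor, a higher number a weaker inhibitor), compound 2 gives 4700 nM, the lowest of the three numbers. Compound 1 gives 11700 nM, a gap that lies beyond the scatter, and compound 3 gives 15900 nM, further still. Compound 2 therefore stands as the strongest inhibitor among those measured.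

Compound 4 `CC(c1ccc(-c2ccccc2)c(F)c1)c1nnc2n1N=C(c1ccc(Br)cc1)CS2` is not yet measured. It differs from compound 2 in one place: 4-bromophenyl in place of 2,4-dichlorophenyl on a carbon with a double bond to nitrogen. Within the data shown here, no measured pair shows this change, so its effect can only be guessed.

The expectation for compound 4 is a step from compound 2 of a 1.4-fold higher number from compound 2 to compound 4 (0.14 log units; within the scatter) in this assay, a small shift toward a weaker inhibitor, close to the scatter. Compound 4 is estimated at 6500 nM, within a range from 2500 nM to 17000 nM.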

Compound 4, half-maximal inhibitory concentration: 7000 nM
Compound 4: middle estimate off by 1.1-fold (0.03 log units), on the low side; measured number inside the range.
By their numbers in this assay, from the lowest: compounds 2, 4, 1 and 3 (each within the scatter of the next, the first and the last beyond it).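

In this assay, 4-bromophenyl in place of 2,4-dichlorophenyl on a carbon with a double bond to nitrogen gives a 1.5-fold higher number from compound 2 to compound 4 (0.17 log units; within the scatter) on the shared core. Among these compounds, this is the first pair to test this position, and it shows that the two aryl groups cannot be told apart in this read-out, with either one giving a compound in the same range. Nothing measured here offers an explanation for this result.

This single step exchanges one halogen pattern for another, changing both the kind and the number of halogens, so it cannot show what each contributes alone. As far as these compounds go, whether the position would accept a phenyl ring carrying an amine, a carboxylic acid or a nitrile in place of halogen remains open.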